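The compounds below may be only part of what the source reports. "The series", "measured", "known", "first", "only" and "open" are said of these compounds alone.

Compound 1 `O=C(Nc1ccccc1F)c1cccc2[nH]c(-c3cccnc3)nc12`: 54.7 uM in an ADME assay on Vero cells (Chlorocebus sabaeus) for cytotoxicity; on this read-out higher numbers stand for lower toxicity in this test and lower numbers for higher toxicity in this test.
Compound 2 `Cc1csc(NC(=O)c2cccc3[nH]c(-c4cccnc4)nc23)n1`: 111 uM in this assay.

For the measured compounds named here, compound 2 stands at the higher of the two numbers measured so far. Going by the values given here, the single measured step, a 2.0-fold higher number from compound 1 to compound 2 (0.31 log units; beyond the scatter), concerns the amide-type nitrogen, where 4-methyl-1,3-thiazol-2-yl replaces 2-fluorophenyl. Compound 3 `Cc1csc(NC(=O)c2cccc3[nH]c(-c4ccncc4)nc23)n1` differs from compound 2 at another place: pyridin-4-yl in place of pyridin-3-yl on an aromatic carbon. Among the compounds with values here, no measured step bears on this part of the shared core; the one known step concerns only the amide side and gives no guide to moving the ring nitrogen of the pyridyl group. With nothing bearing on it, the change from compound 2 to compound 3 is expected to leave this assay unchanged beyond the scatter, an expected step of a 1.1-fold lower number from compound 2 to compound 3 (0.05 log units; within the scatter). Compound 3 is therefore estimated at 100 uM, with a range from 40 uM to 250 uM.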

Compound 3, half-maximal toxic concentration: 111 uM
Beside the measured number, compound 3's estimate is 1.1-fold (0.05 log units) below it; the measured number falls inside the stated range.
By their numbers in this assay, from the lowest: compound 1; then compounds 2 and 3 (each within the scatter of the next).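

For the compounds shown here, replacing pyridin-3-yl with pyridin-4-yl on the aromatic carbon between two ring nitrogen atoms gives no change at the digits printed from compound 2 to compound 3 (within the scatter) in this assay, the first measured step at this position. With the 4-methyl-1,3-thiazol-2-yl amide held in place, this assay therefore does not separate the two pyridyl attachments, whereas the earlier step showed a difference only on the amide side. No available evidence bears on this result.

The compounds shown leave open whether the same holds with 2-fluorophenyl on the amide-type nitrogen, since only the thiazole pair tests the pyridyl change. They also leave open whether a plain phenyl ring, pyridin-2-yl or a saturated amine such as morpholine at this position would shift the number in this assay beyond the scatter.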